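Cycloheptyl for cyclopentyl on the piperidine-bound methylene

The compounds below may be only part of what the source reports. "The series", "measured", "known", "first", "only" and "open" are said of these compounds alone.

Compounds measured so far:
Compound 1, `COc1cc(N)c(Cl)cc1NC(=O)C1CCN(Cc2ccc(Cl)cc2)CC1`, gives 1.2 mg/kg in a functional assay on the whole organism for antagonist activity, with Mus musculus as the target; on this read-out higher numbers stand for an effect only at larger amounts of compound and lower numbers for an effect already at smaller amounts.
Compound 2, `COc1ccc(CN2CCC(C(=O)Nc3cc(Cl)c(N)cc3OC)CC2)cc1`, gives 0.9 mg/kg in this assay.
Compound 3, `COc1cc(N)c(Cl)cc1NC(=O)C1CCN(CC2CCCC2)CC1`, gives in this assay a result of > 10 mg/kg, which is a limit of the assay and not a number.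

Compound 3 thus stands at the limit of > 10 mg/kg in this assay, at which 1 of the 3 values shown sits. Compound 4, `COc1cc(N)c(Cl)cc1NC(=O)C1CCN(CC2CCCCCC2)CC1`, differs from compound 3 by cycloheptyl in place of cyclopentyl on a saturated chain carbon bound to an amine nitrogen in a ring. For the measured compounds named here, two measured steps concern the same position: an at least 8.3-fold higher number from compound 1 to compound 3 (0.92 log units; beyond the scatter) and an at least 11-fold higher number from compound 2 to compound 3 (1.04 log units; beyond the scatter). Both steps exchange an aromatic ring for a saturated one and both lead into the limit; neither measures a change of ring size within saturated rings, so the size of the step from compound 3 to compound 4 in this assay cannot be read from the measured compounds. Since compound 3 already sits at the limit, compound 4 is expected to stay near it, and the expected step is a step that the limit leaves unreadable from compound 3 to compound 4. For compound 4 the estimate in this assay is 15 mg/kg, with a range from 5 mg/kg to 50 mg/kg, most likely again reported only as a limit.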

Compound 4, dose for half-maximal effect: > 10 mg/kg
Compound 4 ended at the assay's limit; the forecaster's own chance of this, stated with the estimate: 70%; the middle value does not contradict the limit.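

Compound 4, like compound 3, sits at a limit of this assay and not at a number: the limit of > 10 mg/kg in this assay, at which 2 of the 4 values shown sit. The loss on leaving the aromatic ring is therefore not tied to cyclopentyl, since cycloheptyl on this saturated chain carbon also gives an at least 11-fold higher number from compound 2 to compound 4 (1.04 log units; beyond the scatter) and an at least 8.3-fold higher number from compound 1 to compound 4 (0.92 log units; beyond the scatter). Among the four compounds, the two carrying 4-chlorophenyl or 4-methoxyphenyl give readable values and the two carrying a saturated ring do not, and none of the four goes against this.

The step between compound 3 and compound 4 cannot be read, so any difference between the two ring sizes stays hidden. As far as these compounds go, whether cyclohexyl, an unsubstituted phenyl or a pyridyl ring on this carbon would give a readable value in this assay remains open.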